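Nitrogen substitution in the biaryl benzylamine series

This account rests on a few compounds, and the source may have more. Where it says the series, first, only, none or still open, it means among the compounds named here.

Within the data shown here, compound 3 `CCNCc1ccc(Cl)c(-c2ccccc2OC)c1` gives 220 nM in an assay on isolated protein for binding affinity to 5-hydroxytryptamine receptor 1D (Homo sapiens) (on this read-out higher numbers stand for weaker inhibition and lower numbers for stronger inhibition), the higher of the two numbers measured so far. Compound 2 `COc1ccccc1-c1cc(C2CCNC2)ccc1Cl` gives 3.4 nM in this assay. Compound 1 `CCCN(CCC)Cc1ccc(Cl)c(-c2ccccc2OC)c1` returns only a limit in this assay, > 10000 nM. Compound 4 `CCN(CC)Cc1ccc(Cl)c(-c2ccccc2OC)c1` is not yet measured; it differs from compound 3 by ethyl in place of hydrogen on an amine nitrogen. The most relevant measured step is an at least 45-fold lower number from compound 1 to compound 3 (1.65 log units; beyond the scatter), which alters the same nitrogen in the opposite direction, with one end sitting at the limit (the limit of > 10000 nM in this assay, at which 1 of the 3 values shown sits). The step of a 65-fold higher number from compound 2 to compound 3 (1.81 log units; beyond the scatter) exchanges the ring-bound group and bears less on this change. A weakening step is therefore expected, a 9.1-fold higher number from compound 3 to compound 4 (0.96 log units; beyond the scatter), smaller than the full move to dipropylamino. Compound 4 is estimated at 2000 nM, within 500 nM to 10000 nM.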

Compound 4, inhibition constant: > 10000 nM
Compound 4 ended at the assay's limit; the forecaster's own chance of this, stated with the estimate: 25%; middle value at least 5.0-fold (0.69 log units) away from the limit.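

Adding one ethyl to the amine nitrogen gives an at least 45-fold higher number from compound 3 to compound 4 (1.65 log units; beyond the scatter), so diethylamino is already enough to reach the limit, and the earlier loss with dipropylamino did not need the propyl chains. Exchanging pyrrolidin-3-yl for (diethylamino)methyl gives an at least 2900-fold higher number from compound 2 to compound 4 (3.46 log units; beyond the scatter). The step between compound 1 and compound 4 cannot be read, as both values are limits: the limit of > 10000 nM in this assay, at which 2 of the 4 values shown sit.

Open, on these data alone, is whether dimethylamino, with a smaller second group on the nitrogen, keeps measurable binding. Also open, as far as these compounds go, is how methylamino or propylamino compares with the ethylamino of compound 3.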